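Varying the amine-bearing side chain on a shared core

This account rests on a few compounds, and the source may have more. Where it says the series, first, only, none or still open, it means among the compounds named here.

Measured so far:
Compound 1 `CCCCC(N)c1cc(C(F)(F)F)ccc1N1CCN(C(=O)CCc2ccc(Cl)cc2Cl)CC1` gives 190 nM in an assay on HEK293 cells for displacement of a labelled ligand from Melanocortin receptor 4 (Homo sapiens); a lower number here means a stronger inhibitor, a higher number a weaker inhibitor.
Compound 2 `CCC(C)[C@H](NC(=O)CN)c1cc(C(F)(F)F)ccc1N1CCN(C(=O)CCc2ccc(Cl)cc2Cl)CC1` gives 18 nM in this assay.
Compound 3 `CN[C@@H](CC(C)C)c1cc(C(F)(F)F)ccc1N1CCN(C(=O)CCc2ccc(Cl)cc2Cl)CC1` has not yet been measured.

Among the compounds with values here, compound 2 has the lowest number of the two measured compounds; the only neighbour is compound 1, and the step of an 11-fold lower number from compound 1 to compound 2 (1.02 log units; beyond the scatter) separates them. Within the data shown here, that step is the single measured change that bears on the next one: extending the free amine of compound 1 into a glycyl amide, with a shorter branched chain, made the binding much tighter.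

Compound 3 goes the other way, with 3-methyl-1-(methylamino)butyl in place of 1-(((aminomethyl)carbonyl)amino)-2-methylbutyl on an aromatic carbon. The glycyl amide that accompanied the strong gain is removed again, leaving a simple methylated amine on a branched chain, a side chain that resembles compound 1 more than compound 2. The expectation is therefore a rise back toward the number of compound 1, though the methyl on the nitrogen and the different chain leave room for the outcome to fall short of a full reversal. Compound 3 is estimated at 80 nM, within 25 nM to 300 nM, a step of a 4.4-fold higher number from compound 2 to compound 3 (0.65 log units; beyond the scatter).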

Compound 3, inhibition constant: 1900 nM
For compound 3 the middle estimate is 24-fold (1.38 log units) below the measured one; the measured number lies above the stated range.
By their numbers in this assay, from the lowest: compound 2; then compound 1; then compound 3.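

Putting 3-methyl-1-(methylamino)butyl in place of 1-(((aminomethyl)carbonyl)amino)-2-methylbutyl on the same aromatic carbon gives a 110-fold higher number from compound 2 to compound 3 (2.02 log units; beyond the scatter) in this assay, so the number moves much further at this position than the earlier pair revealed. Removing the amide-containing side chain also does not simply restore the level of the 1-aminopentyl compound, as there is still a 10-fold higher number from compound 1 to compound 3 (1.00 log units; beyond the scatter), which shows that two side chains lacking that amide can differ clearly from each other. Nothing available here accounts for either shift.

Each step changes more than one feature of the side chain. The contributions of the methyl on the nitrogen, the shape of the carbon chain and the loss of the aminomethyl carbonyl group remain inseparable. An unmethylated amine on the same 3-methylbutyl chain, or an ethyl group on that nitrogen, would help show whether the substituent on the nitrogen or the carbon chain matters more.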